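Aryl swap on the enone chain: indolyl to dimethylphenyl

The compounds below may be only part of what the source reports. "The series", "measured", "known", "first", "only" and "open" are said of these compounds alone.

Measured compounds:
Compound 1, `Cc1ccc(CS(=O)(=O)/C(=C/c2c[nH]c3ccccc23)C(=O)c2ccc(Cl)cc2)cc1`, in a functional assay on DU-145 cells (Homo sapiens) for inhibition, read by trypan blue exclusion, with a stated time of 96 h (on this read-out lower numbers stand for stronger inhibition of growth and higher numbers for weaker inhibition of growth), gives 25000 nM.
Compound 2, `O=C(/C(=C\c1ccc(OC(F)(F)F)cc1)S(=O)(=O)c1ccc(Br)cc1)c1ccc(Br)cc1`, gives 25000 nM.
Compound 3, `O=C(O)c1ccc(C(=O)/C(=C\c2ccc(Br)c([N+](=O)[O-])c2)SCc2ccccc2Cl)cc1`, gives 1000 nM.

Compound 1 stands level with compound 2 at the digits shown; the two share the highest number of the three. Compound 3 sits well apart with a much lower number, a gap beyond the scatter, but compound 3 differs from compound 1 in several places at once, so no single change is isolated by it. For the measured compounds named here, no pair among the measured compounds differs in one place only.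

Compound 4, `Cc1ccc(CS(=O)(=O)/C(=C/c2cc(C)ccc2C)C(=O)c2ccc(Cl)cc2)cc1`, differs from compound 1 in one place: 2,5-dimethylphenyl in place of 1H-indol-3-yl on a double-bonded chain carbon bound to a double-bonded chain carbon. The 1H-indol-3-yl group leaves and a 2,5-dimethylphenyl group enters; the hydrogen-bond donor of compound 1 is lost.

Compound 2, which carries a substituted phenyl on the same chain carbon, gives the same reading as compound 1, so the phenyl-for-indolyl exchange gives no sign of a gain. The expected step of no change at the digits printed from compound 1 to compound 4 (within the scatter) is therefore none beyond the scatter. Compound 4 is estimated at 25000 nM, with a range from 8000 nM to 60000 nM.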

Compound 4, concentration for 50% growth inhibition: 1000 nM
The estimate for compound 4 lay 25-fold (1.40 log units) above the measured number; the measured number lies below the stated range.
By their numbers in this assay, from the lowest: compounds 3 and 4 (each within the scatter of the next); then compounds 1 and 2 (each within the scatter of the next).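

In this assay, for the compounds shown here, the exchange of 1H-indol-3-yl for 2,5-dimethylphenyl on a double-bonded chain carbon bound to a double-bonded chain carbon gives a 25-fold lower number from compound 1 to compound 4 (1.40 log units; beyond the scatter), the only step so far that isolates a single place. The earlier compounds shown here could not show this, as they differ from one another in several places at once; the step now shows that the aryl group at this position can by itself move the read-out well beyond the scatter, and that compound 4 reaches its lower number without the hydrogen-bond donor of the indolyl group. No measurement at hand accounts for the size of this step.

Going by these compounds, a single exchange does not separate the loss of the five-membered ring and its donor from the entry of the two methyl groups, so it remains open whether an unsubstituted phenyl or a phenyl bearing one methoxy group at this position would keep the lower number. Also open, on these data alone, is whether the step keeps its size on a core other than that of compound 1, for instance one carrying an amine.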